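This account rests on a few compounds, and the source may have more. Where it says the series, first, only, none or still open, it means among the compounds named here.

Measured in a functional assay on MCF7 cells (Homo sapiens) for antiproliferative activity, read by MTT assay, with a stated time of 48 h; a higher number here means a weaker inhibitor, a lower number a stronger inhibitor:

- compound 1 `CC(=O)N1N=C(c2ccc3ccccc3c2)OC1c1ccc(Br)cc1` gives 5.07 ug/mL
- compound 2 `CC(=O)N1N=C(c2ccc3ccccc3c2)OC1c1ccccc1Cl` gives 2.36 ug/mL
- compound 3 `CC(=O)N1N=C(c2ccc3ccccc3c2)OC1c1cccnc1` gives 2.61 ug/mL

Compound 3 stands within the scatter of both other compounds, with a 1.1-fold higher number from compound 2 to compound 3 (0.04 log units; within the scatter) and a 1.9-fold lower number from compound 1 to compound 3 (0.29 log units; within the scatter). The latter is also the nearest guide to what comes next, since there 4-bromophenyl gives way to pyridin-3-yl. Compound 4 `CC(=O)N1N=C(c2ccc3ccccc3c2)OC1c1ccc(C)cc1` has 4-methylphenyl in place of pyridin-3-yl on a saturated ring carbon. For the measured compounds named here, no measured step makes this exact exchange, and no measured pair separates methyl from bromo. The two compounds with a substituted phenyl group are themselves apart, with a 2.1-fold lower number from compound 1 to compound 2 (0.33 log units; beyond the scatter), a modest step, so a phenyl group alone does not fix the number. In this assay a small shift towards a higher number is therefore expected, not clearly beyond the scatter. The expected change is a 1.4-fold higher number from compound 3 to compound 4 (0.14 log units; within the scatter). For compound 4 the estimated value is 3.6 ug/mL, with an expected range from 1.7 ug/mL to 7.5 ug/mL.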

Compound 4, half-maximal inhibitory concentration: 2.9 ug/mL
The estimate for compound 4 lay 1.2-fold (0.09 log units) above the measured number; measured number inside the range.
By their numbers in this assay, from the lowest: compounds 2, 3, 4 and 1 (each within the scatter of the next, the first and the last beyond it).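

In this assay, 4-methylphenyl in place of pyridin-3-yl on the saturated ring carbon stays within the scatter (a 1.1-fold higher number from compound 3 to compound 4 (0.05 log units; within the scatter)), so across this pair a six-membered aromatic ring of carbon only and one with a hetero atom are not told apart. For the compounds shown here, the 2-chlorophenyl and 4-methylphenyl groups are not told apart either (a 1.2-fold higher number from compound 2 to compound 4 (0.09 log units; within the scatter)), and the first pair to separate methyl from bromo on the aromatic carbon also stays within the scatter (a 1.7-fold lower number from compound 1 to compound 4 (0.24 log units; within the scatter)), so compound 4 sits within the scatter of all three earlier compounds, although compound 1 and compound 2 lie beyond it from each other. Nothing measured here explains these numbers.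

Still open, on these data alone, is whether an amine, a carboxylic acid or a longer chain in place of the methyl group would move the number beyond the scatter. The compounds shown also all keep the acetyl group, so what another group at that place would do remains unknown.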